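The source may report more compounds than this note shows. Statements on the series, on what has been measured and on what is new or still open speak of the compounds shown alone.

Compound 1 `CCCOC(=O)c1[nH]c(COC(C)=O)c(C(=O)OC(C)(C)C)c1C`: 2700 nM
Compound 2 `Cc1c(C(=O)OC(C)C(C)(C)C)c[nH]c1C(=O)OC(C)CN(C)C`: 390 nM

In an assay on CHO cells for inhibition of metabotropic glutamate receptor 1 (Rattus norvegicus) (a higher number here means a weaker inhibitor, a lower number a stronger inhibitor), compound 1 gives 2700 nM, the higher of the two numbers; compound 2 gives 390 nM, a gap beyond the usual scatter. Compound 3 `CCCOC(=O)c1[nH]c(C=O)c(C(=O)OC(C)(C)C)c1C` has not yet been measured. It differs from compound 1 in one place: formyl in place of acetoxymethyl on an aromatic carbon. Among the compounds with values here, no measured pair shows the effect of this change, so there is no basis to expect a step in this assay beyond the scatter in either direction. Compound 3 is therefore expected to give about 2200 nM, within a range from 700 nM to 7000 nM. The expected step is a 1.2-fold lower number from compound 1 to compound 3 (0.09 log units; within the scatter).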

Compound 3, half-maximal inhibitory concentration: 2000 nM
Compound 3: the middle estimate sits 1.1-fold (0.04 log units) above what was measured; measured number inside the range.
By their numbers in this assay, from the lowest: compound 2; then compounds 3 and 1 (each within the scatter of the next).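

In this assay, placing formyl instead of acetoxymethyl on the aromatic carbon next to the ring nitrogen gives a 1.4-fold lower number from compound 1 to compound 3 (0.13 log units; within the scatter). This position therefore accepts a much shorter group, and one with fewer hydrogen-bond acceptors, without a change that stands out from the scatter. No measurement at hand explains why these two groups give such similar numbers. Still open, on these data alone, is whether an amine or a carboxylic acid on this carbon would move the number beyond the scatter. Also open, as far as these compounds go, is whether a longer chain there would do so.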